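The compounds below may be only part of what the source reports. "The series", "measured", "known", "first", "only" and "open" are said of these compounds alone.

Working notes on the series in a functional assay on HepG2 cells (Homo sapiens) for cytotoxicity, read by MTT assay, with a stated time of 72 h; a higher number here means a weaker inhibitor, a lower number a stronger inhibitor.

Compound 1 `O=C(COc1ccc(-c2cc(=O)c3ccccc3o2)cc1)N1CCN(Cc2ccccc2)CC1` gives only a limit of the assay, > 20000 nM. Compound 2 `COc1ccc(CN2CCC(NC(=O)C(C)(C)Oc3ccc4c(=O)cc(-c5ccccc5)oc4c3)CC2)cc1` gives 8700 nM. Within the data shown here, compound 3 `CC(C)(Oc1ccc2c(=O)cc(-c3ccccc3)oc2c1)C(=O)NC1CCN(Cc2ccccc2)CC1` gives 14000 nM; the step of a 1.6-fold higher number from compound 2 to compound 3 (0.21 log units; within the scatter) is the only measured step between two numbers. Among the two numbers shown, compound 3 carries the higher one, but its distance to compound 2 is within the scatter, so no order between the two can be read.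

Compound 4 `CC(C)(Oc1ccc2c(=O)cc(-c3ccccc3)oc2c1)C(=O)NC1CCN(Cc2ccc(C(F)(F)F)cc2)CC1` differs from compound 3 by trifluoromethyl in place of hydrogen on an aromatic carbon. Among the measured compounds shown here, the one measured step that bears on a substituent change on an aromatic carbon is a 1.6-fold higher number from compound 2 to compound 3 (0.21 log units; within the scatter), which stayed within the scatter. For the measured compounds named here, no measured step involves a trifluoromethyl group, and nothing among the measured compounds points to a shift in either direction for this change. The expectation for the step of a 1.3-fold lower number from compound 3 to compound 4 (0.10 log units; within the scatter) is therefore no shift beyond the scatter, with the usual chance that the assay returns only a limit rather than a number. Compound 4 is accordingly estimated at 11000 nM, with a range from 4500 nM to 28000 nM.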

Compound 4, half-maximal inhibitory concentration: > 20000 nM
Compound 4 was reported as a limit; the forecaster's own chance of this, stated with the estimate: 25%; middle value at least 1.8-fold (0.25 log units) away from the limit.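

In this assay compound 4 gives > 20000 nM, which is a limit of the assay and not a number. At this aromatic carbon, the trifluoromethyl and methoxy groups now give a step beyond the scatter, an at least 2.2-fold higher number from compound 2 to compound 4 (0.36 log units; beyond the scatter), whereas the earlier exchange of methoxy for hydrogen stayed within it, so the position does respond to some changes of substituent in this assay. The exchange of hydrogen for trifluoromethyl reads as an at least 1.4-fold higher number from compound 3 to compound 4 (0.15 log units; that floor lies within the scatter), and since that floor lies within the scatter, this step alone does not establish a shift, while the upper size of both new steps is undefined, as both rest on one limit: the limit of > 20000 nM in this assay, at which 2 of the 4 values shown sit.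

The compounds shown leave open how an amine, a carboxylic acid, a nitrile or a single fluorine on this aromatic carbon would read, and so whether the methoxy and hydrogen compounds mark a general range for this position. From the compounds shown here alone, it also remains open whether any group here can bring the number clearly below those of compound 2 and compound 3, which cannot be ordered against each other.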